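Sulfonyl for carbonyl on the ring nitrogen of compound 1

The source may report more compounds than this note shows. Statements on the series, on what has been measured and on what is new or still open speak of the compounds shown alone.

Compound 1 `CN1CCN(c2ccc(C3=NN(C(=O)c4ccc(C(F)(F)F)cc4)C(c4ccc(N(C)C)cc4)C3)cc2)CC1` carries a (4-(trifluoromethyl)phenyl)carbonyl group on the ring nitrogen of the shared core. Going by the values given here, in a functional assay on HCC1806 cells (Homo sapiens) for inhibition (on this read-out higher numbers stand for weaker inhibition and lower numbers for stronger inhibition), compound 1 gives 5400 nM, the lowest of the three numbers so far, though its neighbours sit within the scatter of it. Compound 2 `CN1CCN(c2ccc(C3=NN(C(=O)/C=C/c4ccccc4)C(c4ccc(N(C)C)cc4)C3)cc2)CC1` gives 9050 nM in this assay, and compound 3 `CN1CCN(c2ccc(C3=NN(S(=O)(=O)c4ccc(F)cc4)C(c4ccc(N(C)C)cc4)C3)cc2)CC1` gives 6100 nM. The steps of a 1.7-fold higher number from compound 1 to compound 2 (0.22 log units; within the scatter), a 1.1-fold higher number from compound 1 to compound 3 (0.05 log units; within the scatter) and a 1.5-fold lower number from compound 2 to compound 3 (0.17 log units; within the scatter) all stay within the scatter, so the three substituents on the ring nitrogen are not told apart by this read-out.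

Compound 4 `CN1CCN(c2ccc(C3=NN(S(=O)(=O)c4ccc(C#N)cc4)C(c4ccc(N(C)C)cc4)C3)cc2)CC1` differs from compound 1 in one place: (4-cyanophenyl)sulfonyl in place of (4-(trifluoromethyl)phenyl)carbonyl on an amine nitrogen in a ring. The step that bears on it is a 1.1-fold higher number from compound 1 to compound 3 (0.05 log units; within the scatter), where the same carbonyl-to-sulfonyl exchange with a (4-fluorophenyl) group moved the number only within the scatter. With a nitrile in place of fluorine, no step beyond the scatter is expected in this assay; the expected step is a 1.1-fold higher number from compound 1 to compound 4 (0.05 log units; within the scatter). Compound 4 is estimated at 6000 nM, with a range from 3000 nM to 12000 nM.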

Compound 4, half-maximal inhibitory concentration: 2990 nM
For compound 4 the middle estimate is 2.0-fold (0.30 log units) above the measured one; measured number outside the range, below it.
By their numbers in this assay, from the lowest: compounds 4, 1, 3 and 2 (each within the scatter of the next, the first and the last beyond it).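

In this assay, going by these compounds alone, the group on the sulfonyl phenyl ring turns out to matter: cyano in place of fluoro on an aromatic carbon gives a 2.0-fold lower number from compound 3 to compound 4 (0.31 log units; beyond the scatter) as a modest step, whereas no step among compound 1, compound 2 and compound 3 left the scatter. The substituent on the ring nitrogen can now also be told apart in one pair, with a 3.0-fold lower number from compound 2 to compound 4 (0.48 log units; beyond the scatter) likewise modest. The sulfonyl series does not separate from the carbonyl compound 1, however, as a 1.8-fold lower number from compound 1 to compound 4 (0.26 log units; within the scatter) stays within the scatter. No measurement at hand accounts for the cyano step.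

Still open, as far as these compounds go, is whether a carboxylic acid or an amine on that aromatic carbon would extend the step seen with the nitrile. Also open, from the compounds shown here alone, is whether the nitrile gives a step of similar size in a (4-cyanophenyl)carbonyl group on the ring nitrogen.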